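A few compounds are considered here, and "the series" means these few. Any claim that something is new, unique, unknown or untested is made for them only; others in the source may bear on it.

Compound 1 `c1cncc(-c2ccccc2OCC2=NCCN2)c1`: 111%
Compound 2 `c1csc(-c2ccccc2OCC2=NCCN2)c1`: 112%
Compound 3 `c1ccc(-c2ccsc2)c(OCC2=NCCN2)c1`: 103%

These numbers come from a functional assay for activation of Alpha-1B adrenergic receptor (Homo sapiens), read by calcium flux; on this read-out higher numbers stand for larger maximal responses and lower numbers for smaller maximal responses. Compound 3 has the lowest of the three numbers, yet its gaps to compound 1 and to compound 2 are both within the usual scatter, so the three compounds are not really separated. Compound 4 `c1ccc(-c2nccs2)c(OCC2=NCCN2)c1` differs from compound 3 in one place: 1,3-thiazol-2-yl in place of thiophen-3-yl on an aromatic carbon. The measured steps that bear on this are all swaps of one aromatic group for another at the same aromatic carbon: a number 8 percentage points lower from compound 1 to compound 3 (within the scatter), a number 9 percentage points lower from compound 2 to compound 3 (within the scatter) and a number 1 percentage points higher from compound 1 to compound 2 (within the scatter), each within the scatter. A further swap of this kind is therefore expected to change the maximal response little, with the step of a number 3 percentage points higher from compound 3 to compound 4 (within the scatter) estimated. Compound 4 is expected to give 106%, in the range 90% to 122%.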

Compound 4, largest response reached (reported as maximum), in percent of the reference or control that the assay uses: 100%
The estimate for compound 4 lay 6 percentage points above the measured number, and the stated range covers the measured number.
By their numbers in this assay, from the lowest: compounds 4, 3, 1 and 2 (each within the scatter of the next, the first and the last beyond it).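

In this assay, for the compounds shown here, 1,3-thiazol-2-yl is the first group at this aromatic carbon to open gaps beyond the scatter, though modest ones (a number 12 percentage points lower from compound 2 to compound 4 (beyond the scatter)) and (a number 11 percentage points lower from compound 1 to compound 4 (beyond the scatter)). Against thiophen-3-yl it remains within the scatter (a number 3 percentage points lower from compound 3 to compound 4 (within the scatter)), so the change separates compound 4 from only two of the three earlier compounds. Nothing shown explains these gaps.

All four compounds carry an aromatic ring at this carbon. From the compounds shown here alone, what a non-aromatic group, such as an amine or a carboxylic acid, would do there remains open.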